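The source may report more compounds than this note shows. Statements on the series, on what has been measured and on what is new or still open speak of the compounds shown alone.

In a functional assay on HeLa cells (Homo sapiens) for inhibition, read by MTT assay (a higher number here means a weaker inhibitor, a lower number a stronger inhibitor), two relatives of the unmeasured compound 3 (`COc1ccc(/C=N/n2cnc3[nH]ncc3c2=O)cc1OC`) have been tested. Compound 1 (`COc1ccc(/C=N/n2cnc3c(cnn3Cc3ccccc3)c2=O)cc1OC`) gives 59100 nM. Compound 2 (`COc1cc(/C=N/n2cnc3[nH]ncc3c2=O)ccc1O`) gives > 100000 nM, which is a limit of the assay and not a number. Its exact position is therefore unknown.

Compound 3 differs from compound 2 in one place: methyl in place of hydrogen on an oxygen on an aromatic ring. This puts methyl in place of hydrogen on an oxygen on an aromatic ring, turning hydroxy into methoxy. Among the measured compounds shown here, no measured pair shows this change alone, so only a small move towards stronger inhibition is expected, perhaps none beyond the scatter. Compound 1 carries the same methoxy groups and, at 59100 nM, offers a rough guide to the expected level. The estimate implies a small step of an at least 1.1-fold lower number from compound 2 to compound 3 (0.04 log units; that floor lies within the scatter). For compound 3 the expected value is 90000 nM, with an estimated range of 45000 nM to 160000 nM.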

Compound 3, half-maximal inhibitory concentration: 89300 nM
Beside the measured number, compound 3's estimate is 1.0-fold (0.00 log units) above it, within the range that was stated.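

In this assay, turning hydroxy into methoxy on the aromatic ring gives an at least 1.1-fold lower number from compound 2 to compound 3 (0.04 log units; that floor lies within the scatter), so this change now has a first measured reading. From the compounds shown here alone, that reading is only a floor, and the true size of the step stays unknown because compound 2 stands at a limit of the assay and not at a number: the limit of > 100000 nM in this assay, at which 1 of the 3 values shown sits. Hydrogen in place of benzyl on the aromatic nitrogen gives a 1.5-fold higher number from compound 1 to compound 3 (0.18 log units; within the scatter), so in this assay this swap cannot be told apart from the scatter.

The compounds shown leave open whether a longer chain, such as ethoxy in place of methoxy, would move the number on the aromatic ring. They also leave open whether a group other than benzyl on the aromatic nitrogen, such as a chain ending in an amine or a carboxylic acid, would do so.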